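A few compounds are considered here, and "the series" means these few. Any claim that something is new, unique, unknown or untested is made for them only; others in the source may bear on it.

Measured so far:
compound 1, `COc1c(C)ccc2c1CCC2c1ncc[nH]1` — > 10000 nM in a functional assay on CHO cells for agonist activity at Alpha-1D adrenergic receptor (Homo sapiens), read by FLIPR and calcium flux; on this read-out higher numbers stand for an effect only at larger amounts of compound and lower numbers for an effect already at smaller amounts
compound 2, `Clc1ccc2c(c1-c1ccn[nH]1)CCC2c1ncc[nH]1` — > 10000 nM in this assay

For compound 2 the reading of > 10000 nM is a limit of the assay, not a number. For compound 1 the reading of > 10000 nM is likewise a limit. For the measured compounds named here, compound 2 thus stands at the limit of > 10000 nM in this assay, at which 2 of the 2 values shown sit; no step between measured compounds can be read, and no order between compound 1 and compound 2 follows from the data.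

Compound 3, `COc1c(Cl)ccc2c1CCC2c1ncc[nH]1`, differs from compound 2 in one place: methoxy in place of 1H-pyrazol-5-yl on an aromatic carbon. Compound 3 carries the methoxy seen in compound 1 and the chloro seen in compound 2, both of which sit at the limit. No step beyond the scatter is expected from compound 2 to compound 3 in this assay, that is a step that the limit leaves unreadable from compound 2 to compound 3, and a further limit is the likelier outcome. Compound 3 is estimated at 15000 nM, ranging from 5000 nM to 50000 nM.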

Compound 3, half-maximal effective concentration: > 10000 nM
Compound 3: no number, only a limit (the forecaster's own chance of this, stated with the estimate: 75%); the middle value does not contradict the limit.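

No step can be read between compound 1, compound 2 and compound 3, as the reading for compound 3 is again a limit and not a number: the limit of > 10000 nM in this assay, at which 3 of the 3 values shown sit.

The compounds shown leave open whether any substituent on the shared core gives a measurable half-maximal effective concentration in this assay and how the groups would rank there.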